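Trifluoromethyl for Fluoro on a Cyclic Nucleotide Core

The compounds below may be only part of what the source reports. "The series", "measured", "known", "first", "only" and "open" are said of these compounds alone.

Compound 1 `O=c1[nH]c(=O)n([C@H]2C[C@@H]3O[PH](O)(O)OC[C@H]3O2)cc1F` is tested in a functional assay on L1210 cells (Mus musculus) for antiproliferative activity (on this read-out lower numbers stand for stronger inhibition and higher numbers for weaker inhibition), and gives 7.4 ug/mL, the only numerical result in hand. Compound 2 `O=c1[nH]c(=O)n([C@H]2C[C@@H]3OP(=O)(OCc4ccccc4)OC[C@H]3O2)cc1I` reaches only a limit of the assay in this assay, reported as > 100 ug/mL. Going by the values given here, that limit, (the limit of > 100 ug/mL in this assay, at which 1 of the 2 values shown sits), is the sole other point of comparison. Compound 3 `O=c1[nH]c(=O)n([C@H]2C[C@@H]3O[PH](O)(O)OC[C@H]3O2)cc1C(F)(F)F` has not yet been tested. Its change from compound 1 is trifluoromethyl in place of fluoro on an aromatic carbon. Among the compounds with values here, no measured pair shares this change, so the expected step in this assay is small, a 1.5-fold lower number from compound 1 to compound 3 (0.17 log units; within the scatter), likely not beyond the usual scatter. Compound 3 is therefore expected to give about 5 ug/mL, in a range from 1 ug/mL to 25 ug/mL.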

Compound 3, concentration for 50% inhibition: 22 ug/mL
Beside the measured number, compound 3's estimate is 4.4-fold (0.64 log units) below it, within the range that was stated.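

In this assay, putting trifluoromethyl in place of fluoro on this aromatic carbon gives a 3.0-fold higher number from compound 1 to compound 3 (0.47 log units; beyond the scatter), so inhibition at this position responds to the change and weakens modestly rather than disappearing. Going by these compounds alone, this is the first step at this position that can be read, since the compounds compared differ in this one place only. No measurement shown bears on why the number rises. The compounds shown leave open how methyl, a nitrile or an amine on this carbon would compare with fluoro.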